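The compounds below may be only part of what the source reports. "The series", "measured", "known", "first", "only" and "open" are said of these compounds alone.

Measured in a physicochemical assay for solubility, with a stated time of 3 days, at pH 2; a higher number here means a more soluble compound, a lower number a less soluble compound:
- Compound 1 `NC(=O)c1ccc2[nH]c(-c3ccc(OCC4CCCNC4)cc3)nc2c1`: "not determined" (no result reported)
- Compound 2 `NC(=O)c1ccc2[nH]c(-c3ccc(OCCC4CCN(Cc5ccccc5)CC4)cc3)nc2c1`: 110000 nM
- Compound 3 `COc1ccc(CN2CCC(CCOc3ccc(-c4nc5cc(C(N)=O)ccc5[nH]4)cc3)CC2)cc1`: > 400000 nM, a limit of the assay

Compound 3 gives no number in this assay, only the limit > 400000 nM. Its standing therefore rests on (the limit of > 400000 nM in this assay, at which 1 of the 3 values shown sits). The next compound, compound 4 `NC(=O)c1ccc2[nH]c(-c3ccc(OCCC4CCN(C(=O)c5ccccc5)CC4)cc3)nc2c1`, has benzoyl in place of 4-methoxybenzyl on an amine nitrogen in a ring, and the change is counted as benzoyl in place of 4-methoxybenzyl on an amine nitrogen in a ring.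

Within the data shown here, only one measured step is available, an at least 3.6-fold higher number from compound 2 to compound 3 (0.56 log units; beyond the scatter), with methoxy in place of hydrogen on an aromatic carbon. That step bears on compound 4 only in part, since the methoxy leaves with the 4-methoxybenzyl group. Among the measured compounds shown here, no measured step covers a benzoyl group at this nitrogen.

Compound 4 carries no methoxy, and compound 2, which also lacks it, gives 110000 nM, so that value is the nearest guide to what is expected. A drop of at least the size of the measured step is therefore expected, and the true size stays uncertain because compound 3 gives only the limit > 400000 nM. The expected step is an at least 5.0-fold lower number from compound 3 to compound 4 (0.69 log units; beyond the scatter). For compound 4 the estimated value is 80000 nM, with an expected range from 20000 nM to 300000 nM.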

Compound 4, solubility: 3000 nM
Beside the measured number, compound 4's estimate is 27-fold (1.43 log units) above it; measured number outside the range, below it.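

The earlier compounds shown here showed only what methoxy on an aromatic carbon of the benzyl group does, with the amine nitrogen in the ring still carrying a benzyl-type group. Compound 4 shows that the group on this nitrogen is a far more sensitive point in this assay: with benzoyl in place of benzyl there is a 37-fold lower number from compound 2 to compound 4 (1.56 log units; beyond the scatter), a large step beyond the scatter, and with benzoyl in place of 4-methoxybenzyl there is an at least 130-fold lower number from compound 3 to compound 4 (2.12 log units; beyond the scatter). The second of these steps gives only a lower bound on its size, as compound 3 stands at a limit and not at a number: the limit of > 400000 nM in this assay, at which 1 of the 4 values shown sits.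

The compounds shown leave open whether the large step goes with the carbonyl on the nitrogen itself or with the benzoyl group as a whole, and an acetyl or a 4-methoxybenzoyl group at the same nitrogen would separate the two. They also leave open whether a methoxy on the benzoyl ring would give a step like the one seen on the benzyl ring, or whether a sulfonyl link to the same aromatic ring would behave as the carbonyl does.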